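The source may report more compounds than this note shows. Statements on the series, on what has been measured and on what is new or still open speak of the compounds shown alone.

Measured so far:
- Compound 1 `c1ccc2c(c1)CC(CCCN1CCN(c3cccc4c3OCCO4)CC1)C2` gives 0.63 mg/kg in a functional assay on the whole organism for antagonist activity, with Rattus norvegicus as the target; a lower number here means that less compound is needed, a higher number that more compound is needed for the effect.
- Compound 2 `C1=C(CCN2CCN(c3cccc4c3OCCO4)CC2)c2ccccc2C1` gives 0.63 mg/kg in this assay.

Compound 2 stands level with compound 1 at the digits shown, and the two values lie within the usual scatter of each other, so nothing separates them. Compound 3 `c1ccc2c(c1)CC(CCN1CCN(c3cccc4c3OCCO4)CC1)C2` is not yet measured. It differs from compound 2 in one place: a group of 9 heavy atoms (9 carbon; one five-membered non-aromatic ring of carbon only, one six-membered aromatic ring of carbon only) in place of a group of 9 heavy atoms (9 carbon; one five-membered non-aromatic ring of carbon only, one six-membered aromatic ring of carbon only), on a saturated chain carbon, two bonds along the chain from an amine nitrogen in a ring. The group that leaves carries one double bond outside aromatic rings; the 2,3-dihydro-1H-inden-2-yl group that enters carries none, and it is the same group already present in compound 1. Since both measured compounds sit at the same minimum effective dose, no step beyond the scatter is expected from compound 2 to compound 3, in either direction. Compound 3 is therefore estimated at 0.63 mg/kg, with a range of 0.25 mg/kg to 1.6 mg/kg, the expected step being no change at the digits printed from compound 2 to compound 3 (within the scatter).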

Compound 3, minimum effective dose: 0.16 mg/kg
Compound 3: middle estimate off by 3.9-fold (0.60 log units), on the high side; the whole stated range lies above it.
By their numbers in this assay, from the lowest: compound 3; then compounds 1 and 2 (each within the scatter of the next).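

The level values of the first two compounds gave no sign that this part of the molecule matters. In this assay, the swap on the saturated chain carbon, two bonds along the chain from an amine nitrogen in a ring, gives a 3.9-fold lower number from compound 2 to compound 3 (0.60 log units; beyond the scatter). The group count stays at 9 heavy atoms, all carbon, with the same two rings, and the clear difference is that the double bond outside aromatic rings is gone, so this one feature goes with a step beyond the scatter, though nothing here explains how it does so.

This is one pair in one whole-animal test, so it cannot show whether the lower dose holds for other groups at this place. A cyclohexyl or phenyl group in place of the 2,3-dihydro-1H-inden-2-yl group would test how much of that ring system is needed.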